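Bromo for Chloro on the Fluorinated Core

The source may hold more compounds than are shown below. What is called first, only, known or untested is meant among the compounds shown, and "the series" means these compounds.

Compound 1 `Cn1ccc2c(Oc3ccc(NC(=O)c4cc5cccnc5n(-c5ccc(Cl)cc5)c4=O)cc3)ccnc21` and compound 2 `Cn1ccc2c(Oc3ccc(NC(=O)c4cc5cccnc5n(-c5ccc(Br)cc5)c4=O)cc3)ccnc21` share one core and differ by bromo in place of chloro on an aromatic carbon. In a functional assay on HT-29 cells (Homo sapiens) for antiproliferative activity, read by MTT assay, with a stated time of 72 h (on this read-out lower numbers stand for stronger inhibition and higher numbers for weaker inhibition), compound 1 gives 730 nM and compound 2 gives 690 nM; the step is a 1.1-fold lower number from compound 1 to compound 2 (0.02 log units; within the scatter), so these two numbers show no change between them. Compound 3 `Cn1ccc2c(Oc3ccc(NC(=O)c4cc5cccnc5n(-c5ccc(Cl)cc5)c4=O)cc3F)ccnc21` differs from compound 1 by fluoro in place of hydrogen on an aromatic carbon. In this assay compound 3 gives 220 nM, and the step is a 3.3-fold lower number from compound 1 to compound 3 (0.52 log units; beyond the scatter). Compound 4 `Cn1ccc2c(Oc3ccc(NC(=O)c4cc5cccnc5n(-c5ccc(Br)cc5)c4=O)cc3F)ccnc21` has not yet been measured; it differs from compound 3 by bromo in place of chloro on an aromatic carbon, the same change already seen between compound 1 and compound 2. Because the earlier step was a 1.1-fold lower number from compound 1 to compound 2 (0.02 log units; within the scatter), little movement is expected. For compound 4 the expected step is a 1.0-fold lower number from compound 3 to compound 4 (0.02 log units; within the scatter). In this assay compound 4 is estimated at 210 nM, with a range from 100 nM to 450 nM.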

Compound 4, half-maximal inhibitory concentration: 330 nM
For compound 4 the middle estimate is 1.6-fold (0.20 log units) below the measured one, within the range that was stated.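

In this assay, bromo in place of chloro again leaves the number without a clear shift on the core of compound 3, with a 1.5-fold higher number from compound 3 to compound 4 (0.18 log units; within the scatter), and the two readings of this change agree: the same change on two cores in this assay, a 1.1-fold lower number (0.02 log units; within the scatter) from compound 1 to compound 2 and a 1.5-fold higher number (0.18 log units; within the scatter) from compound 3 to compound 4, 1.6-fold (0.20 log units) apart, within the scatter of two such steps. The fluoro change also carries over to the bromo pair, with a 2.1-fold lower number from compound 2 to compound 4 (0.32 log units; beyond the scatter), and stays beyond the scatter on both cores: the same change on two cores in this assay, a 3.3-fold lower number (0.52 log units; beyond the scatter) from compound 1 to compound 3 and a 2.1-fold lower number (0.32 log units; beyond the scatter) from compound 2 to compound 4, 1.6-fold (0.20 log units) apart, within the scatter of two such steps. This shows both changes carrying across these four compounds only; it does not show that either would hold on any other core.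

The compounds shown leave open whether an amine or a carboxylic acid in place of the chloro or bromo would follow the same course. They also leave open whether the fluoro step would persist alongside such a group.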